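Cell tolerance notes: from compound 1 toward compound 3

The source may report more compounds than this note shows. Statements on the series, on what has been measured and on what is new or still open speak of the compounds shown alone.

Compound 1 `O=c1ncccn1SCCc1ccc(Nc2ncc(Cc3c(F)cccc3F)o2)cc1` has been examined in an ADME assay on MT2 cells (Homo sapiens) for cytotoxicity, read by MTT assay; a higher number here means that more compound is tolerated, a lower number that less compound is tolerated. In this assay compound 1 is recorded only as the limit > 100000 nM, which is a limit of the measurement and not a number. Among the measured compounds shown here, the one other measured member, compound 2 `Clc1cccc(Cl)c1Cc1nnc(Nc2ccc(COCc3cccnc3)cc2)o1`, built on a different core, gives 81000 nM in this assay. Taken together the two values show one number and one limit, the limit being (the limit of > 100000 nM in this assay, at which 1 of the 2 values shown sits).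

Compound 3 `Fc1cccc(F)c1Cc1cnc(Nc2ccc(COCc3ccco3)cc2)o1` keeps the core of compound 1 and differs from it by a group of 7 heavy atoms (5 carbon, 2 oxygen; one five-membered aromatic ring with 1 hetero atom) in place of a group of 9 heavy atoms (5 carbon, 2 nitrogen, 1 oxygen, 1 sulfur; one six-membered aromatic ring with 2 hetero atoms), on a saturated chain carbon bound to an aromatic carbon. For the measured compounds named here, no measured step of this kind is available among the present compounds, so the direction has to be estimated rather than read. The step of an at least 1.1-fold lower number from compound 1 to compound 3 (0.04 log units; that floor lies within the scatter) is expected to be small, likely within the scatter, with compound 3 expected to remain well tolerated. For compound 3 in this assay the estimate is 90000 nM, with an expected range from 40000 nM to 150000 nM.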

Compound 3, half-maximal cytotoxic concentration: 31000 nM
Beside the measured number, compound 3's estimate is 2.9-fold (0.46 log units) above it; the whole stated range lies above it.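

In this assay, the series now has its first readable step, on a saturated chain carbon bound to an aromatic carbon: an at least 3.2-fold lower number from compound 1 to compound 3 (0.50 log units; beyond the scatter). This place is therefore not indifferent to the group it carries: placing (furan-2-yl)methoxy there moves the read-out beyond the scatter, which compounds without a shared step could not show. The step is only a floor, and its full size stays unknown, because compound 1 is recorded as a limit: the limit of > 100000 nM in this assay, at which 1 of the 3 values shown sits.

A single exchange cannot separate the contribution of the entering furan ring from that of the leaving group with its sulfur atom. Also open, as far as these compounds go, is how a simple benzyloxy group, an amine or a carboxylic acid at this place would stand.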